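The source may hold more compounds than are shown below. What is called first, only, known or untested is meant among the compounds shown, and "the series" means these compounds.

Series notes. The three measured compounds share one core and differ only in the group on the amide carbonyl carbon. Compound 1 `COc1cc(F)c(NC(=O)c2ccnc(O)c2)cc1Nc1nccc(-c2cn(C)c3ccccc23)n1` gives 5920 nM in a functional assay on NCI-H1975 cells (Homo sapiens) for antiproliferative activity, read by MTT assay, with a stated time of 72 h; a lower number here means a stronger inhibitor, a higher number a weaker inhibitor. Compound 2 `COc1cc(F)c(NC(=O)c2ccccn2)cc1Nc1nccc(-c2cn(C)c3ccccc23)n1` gives 16500 nM in this assay, and compound 3 `COc1cc(F)c(NC(=O)c2nccn2C)cc1Nc1nccc(-c2cn(C)c3ccccc23)n1` gives 10600 nM. Compound 1 holds the lowest of the three numbers: the step of a 2.8-fold higher number from compound 1 to compound 2 (0.45 log units; beyond the scatter) is beyond the scatter, whereas a 1.8-fold higher number from compound 1 to compound 3 (0.25 log units; within the scatter) and a 1.6-fold lower number from compound 2 to compound 3 (0.19 log units; within the scatter) are within it, so only compound 2 is separated from compound 1.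

Compound 4 `COc1cc(N(C)CCN(C)C)c(NC(=O)c2ccnc(O)c2)cc1Nc1nccc(-c2cn(C)c3ccccc23)n1` keeps the amide of compound 1 and changes a different place: (2-(dimethylamino)ethyl)(methyl)amino in place of fluoro on an aromatic carbon. For the measured compounds named here, none of the measured steps bears on this position; all three concern the carbonyl carbon, and the largest of them, a 2.8-fold higher number from compound 1 to compound 2 (0.45 log units; beyond the scatter), is modest. Going by the values given here, the new group enters with seven heavy atoms where a single fluorine stood, and no measured pair tests anything like it, so neither direction nor size of the step in this assay can be read from the measured compounds and the range must stay wide. Compound 4 is expected at 2500 nM, within a range from 250 nM to 25000 nM. That estimate corresponds to the step of a 2.4-fold lower number from compound 1 to compound 4 (0.37 log units; beyond the scatter).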

Compound 4, half-maximal inhibitory concentration: 12000 nM
For compound 4 the middle estimate is 4.8-fold (0.68 log units) below the measured one, within the range that was stated.
By their numbers in this assay, from the lowest: compounds 1, 3, 4 and 2 (each within the scatter of the next, the first and the last beyond it).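

For the compounds shown here, this is the first measured step at the aromatic carbon ortho to the ((2-hydroxypyridin-4-yl)carbonyl)amino group: in this assay, (2-(dimethylamino)ethyl)(methyl)amino in place of fluoro gives a 2.0-fold higher number from compound 1 to compound 4 (0.31 log units; beyond the scatter) and so lies beyond the scatter, though modest in size. Thus, on this single pair, the larger chain raises the number rather than lowering it, yet the change of 7 heavy atoms for 1 produces no large step. No evidence is available to explain this result.

The compounds shown leave open whether this step belongs to this particular chain or to the loss of fluoro, which a dimethylamino group, a methoxy group or a 4-methylpiperazin-1-yl ring at this carbon would help to separate. Also open, on these data alone, is whether the step carries over to the pyridin-2-yl and 1-methyl-1H-imidazol-2-yl amides.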